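The source may report more compounds than this note shows. Statements on the series, on what has been measured and on what is new or still open speak of the compounds shown alone.

Compound 1 `COc1ccccc1N1CCN(CCCOc2ccc(C(=O)Nc3ccccc3OCCCC(=O)O)cc2)CC1` and compound 2 `COc1ccccc1N1CCN(CCC(Oc2ccc(NC(=O)c3ccccc3OCCCC(=O)O)cc2)c2ccccc2)CC1` share a core and were tested in an assay on Prostate gland (Oryctolagus cuniculus) for inhibition of Adrenergic receptor alpha-1 (Homo sapiens); a lower number here means tighter binding, a higher number weaker binding. In this assay compound 1 gives 100 nM, and compound 2 gives 79.4 nM; the two numbers sit within the scatter of each other, so neither can be called the tighter binder, and compound 1 simply carries the higher of the two numbers recorded.

Compound 3 `COc1ccccc1N1CCN(CCC(Oc2ccc(C(=O)Nc3ccccc3OCCCC(=O)O)cc2)c2ccc(C)cc2)CC1` has not yet been measured. It differs from compound 1 in one place: 4-methylphenyl in place of hydrogen on a saturated chain carbon bound to an oxygen on an aromatic ring and a saturated chain carbon. For the measured compounds named here, no measured pair shows the effect of this change on its own, so any expectation rests on the values shown. Compound 3 is expected to come out at 70 nM, within 25 nM to 200 nM, a step from compound 1 to compound 3 of a 1.4-fold lower number from compound 1 to compound 3 (0.15 log units; within the scatter) that is expected to stay within or only modestly beyond the scatter, leaning toward tighter binding.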

Compound 3, dissociation constant: 15.9 nM
Compound 3: middle estimate off by 4.4-fold (0.64 log units), on the high side, outside the stated range (below it).
By their numbers in this assay, from the lowest: compound 3; then compounds 2 and 1 (each within the scatter of the next).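

In this assay, putting 4-methylphenyl in place of hydrogen on the saturated chain carbon bound to an oxygen on an aromatic ring and a saturated chain carbon gives a 6.3-fold lower number from compound 1 to compound 3 (0.80 log units; beyond the scatter) and so moves the number toward tighter binding. This is the first pair shown that differs in one place, and it shows that this carbon tolerates a group of this size without loss of binding. Nothing shown explains the size of this step.

As far as these compounds go, it remains open whether a methyl group or an unsubstituted phenyl at this carbon, on the core of compound 1, would give a similar step, or whether a methoxy or chloro group on the ring would. From the compounds shown here alone, this step also rests on a single pair, so whether it carries over to other cores is unknown.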